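Cytotoxicity series on the shared core: a sulfonyl swap

The compounds below may be only part of what the source reports. "The series", "measured", "known", "first", "only" and "open" are said of these compounds alone.

Compound 1 `Cc1nnc(-c2cccc(-c3ccc(C(=O)N(Cc4cccc(OCCCCCC(=O)O)c4)C(C)C)cc3)c2)o1` sits at the assay limit in an ADME assay on HepG2 cells (Homo sapiens) for cytotoxicity, read by CellTiter-Glo and resazurin assay, with a stated time of 72 h (on this read-out lower numbers stand for an effect already at smaller amounts and higher numbers for an effect only at larger amounts of compound), where compound 1 gives > 26000 nM, a limit rather than a number. Compound 2 `CC(C)N(Cc1cccc(OCCCCCC(=O)O)c1)C(=O)c1ccc(-c2cc3ccccc3n2S(=O)(=O)c2ccccc2)cc1` likewise gives > 26000 nM in this assay, again a limit. Both values sit at the limit of > 26000 nM in this assay, at which 2 of the 2 values shown sit. Compound 3 `CC(C)N(Cc1cccc(OCCCCCC(=O)O)c1)C(=O)c1ccc(-c2cccc(S(C)(=O)=O)c2)cc1` carries methylsulfonyl in place of 5-methyl-1,3,4-oxadiazol-2-yl on an aromatic carbon. Among the measured compounds shown here, no measured pair shows a step for this change, so no step beyond the scatter is expected. Compound 3 is expected to remain at the limit, with a step that the limit leaves unreadable from compound 1 to compound 3. The estimate for compound 3 in this assay is 40000 nM, ranging from 20000 nM to 80000 nM.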

Compound 3, half-maximal effective concentration: > 26000 nM
Compound 3: no number, only a limit (the forecaster's own chance of this, stated with the estimate: 85%); the middle value does not contradict the limit.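

Compound 1 and compound 3 both stand at a limit; no step can be read for methylsulfonyl in place of 5-methyl-1,3,4-oxadiazol-2-yl. Left open is which change to the shared core, if any, would bring a value inside the readable range of this assay.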